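Adding a Methyl to an Inactive Stilbene Analogue

The source may hold more compounds than are shown below. What is called first, only, known or untested is meant among the compounds shown, and "the series" means these compounds.

Of the compounds shown here, two have been tested in an assay on cells for inhibition of Amine oxidase [flavin-containing] A (Homo sapiens), read by Amplex Red, with a stated time of 30 min; a lower number here means a stronger inhibitor, a higher number a weaker inhibitor. Compound 1, `Cc1cccc(/N=N/c2ccc(C3=NNC(=O)CO3)cc2)c1`, reaches only the limit of the assay, > 100000 nM, and not a number. Compound 2, `O=C1COC(c2ccc(/C=C/c3ccccc3)cc2)=NN1`, likewise sits at a limit, > 100000 nM. Both results rest at the limit of > 100000 nM in this assay, at which 2 of the 2 values shown sit, so compound 2 stands at the edge of what the test can report. Compound 3, `Cc1cccc(/C=C/c2ccc(C3=NNC(=O)CO3)cc2)c1`, differs from compound 2 by methyl in place of hydrogen on an aromatic carbon. No step between measured compounds is shown, and the change is small, so the step that the limit leaves unreadable from compound 2 to compound 3 is expected to be none beyond the scatter. Compound 3 is estimated near 200000 nM, within 50000 nM to 1000000 nM.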

Compound 3, half-maximal inhibitory concentration: > 100000 nM
Compound 3 was reported as a limit; the forecaster's own chance of this, stated with the estimate: 85%; the middle value lies beyond the limit too.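

Going by these compounds alone, compound 3 also gives only a limit of the assay, > 100000 nM, so no step from compound 2 to compound 3 can be read: the limit of > 100000 nM in this assay, at which 3 of the 3 values shown sit. As far as these compounds go, whether the methyl changes inhibition at all stays open.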